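A Cycloheptyl Amide Set Against a Difluorophenyl One

This account rests on a few compounds, and the source may have more. Where it says the series, first, only, none or still open, it means among the compounds named here.

Of the compounds shown here, three built on the shared core have been tested. Compound 1 `CC1CCCCC1N(CCCCCCN1C[C@H](O)[C@@H](O)[C@H](O)[C@H]1CO)C(=O)OC(C)(C)C`, compound 2 `CC(=O)N(CCCCCCN1C[C@H](O)[C@@H](O)[C@H](O)[C@H]1CO)C1CCCCC1` and compound 3 `CC(C)(C)C(=O)N(CCCCCCN1C[C@H](O)[C@@H](O)[C@H](O)[C@H]1CO)c1cc(F)ccc1F` carry different groups on the amide-type nitrogen at the end of the chain. In an ADME assay on Huh-7 cells (Homo sapiens) for cytotoxicity, read by MTT assay (a lower number here means that less compound is tolerated, a higher number that more compound is tolerated), compound 1 gives 240000 nM. Compound 2 reaches only a limit of the assay, > 500000 nM. Compound 3 likewise sits at a limit in this assay, > 500000 nM. Because two of the three values rest at that limit (the limit of > 500000 nM in this assay, at which 2 of the 3 values shown sit), compound 3 stands where the cells tolerate all that was offered, with no number to set against compound 2. Compound 4 `CC(C)(C)C(=O)N(CCCCCCN1C[C@H](O)[C@@H](O)[C@H](O)[C@H]1CO)C1CCCCCC1` differs from compound 3 by cycloheptyl in place of 2,5-difluorophenyl on an amide-type nitrogen. Among the measured compounds shown here, no measured pair differing in one place is available, so the size of this change in this assay cannot be read from a neighbouring step. The value of compound 4 in this assay is expected to remain close to the limit, estimated at 400000 nM with a range from 150000 nM to 600000 nM. The step that this estimate means, an at least 1.2-fold lower number from compound 3 to compound 4 (0.09 log units; that floor lies within the scatter), is expected to fall within the scatter.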

Compound 4, half-maximal cytotoxic concentration: > 500000 nM
Compound 4 was reported as a limit (the forecaster's own chance of this, stated with the estimate: 55%); at least 1.2-fold (0.09 log units) between middle value and limit.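

In this assay, compound 3 and compound 4 both rest at a limit, and no step can be read from one to the other: the limit of > 500000 nM in this assay, at which 3 of the 4 values shown sit.

The compounds shown leave open whether cycloheptyl in place of 2,5-difluorophenyl on an amide-type nitrogen changes how much compound the cells tolerate.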